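Phenoxy in place of heptyl on the amide chain

The compounds below may be only part of what the source reports. "The series", "measured", "known", "first", "only" and "open" are said of these compounds alone.

Compound 1 `CCCCCCCCCCCCCCCC(=O)Nc1c(C)cc(C)c2c1OC(C)(C)C2`, compound 2 `CCCCCCCCCCCCC(C)(C)C(=O)Nc1c(C)cc(C)c2c1OC(C)(C)C2` and compound 3 `Cc1cc(C)c(NC(=O)C(C)(C)CCCCCc2ccccc2)c2c1CC(C)(C)O2` share one core and differ only in the acyl part of the amide. In an assay for inhibition of acyl-CoA:cholesterol acyltransferase (Oryctolagus cuniculus), using microsomes (a lower number here means a stronger inhibitor, a higher number a weaker inhibitor), compound 1 gives 26 nM. Compound 2 gives 33 nM, the second highest of the three numbers: the gap to compound 1 is within the scatter, while compound 3 gives 120 nM and is the furthest from compound 2. The single-place step among the measured compounds is a 3.6-fold higher number from compound 2 to compound 3 (0.56 log units; beyond the scatter).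

Compound 4 `Cc1cc(C)c(NC(=O)C(C)(C)CCCCCOc2ccccc2)c2c1CC(C)(C)O2` has not been measured. It differs from compound 2 by phenoxy in place of heptyl on a saturated chain carbon, six bonds along the chain from a carbonyl carbon. This is the same place on the chain as in the measured step, with phenoxy rather than phenyl entering for heptyl, so that step is the one that bears on it; it was modest and beyond the scatter, toward a higher number. The same direction and a similar size are expected here, an estimated step of a 3.0-fold higher number from compound 2 to compound 4 (0.48 log units; beyond the scatter). Compound 4 is therefore expected to give about 100 nM, with a range from 40 nM to 300 nM.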

Compound 4, half-maximal inhibitory concentration: 86 nM
Beside the measured number, compound 4's estimate is 1.2-fold (0.07 log units) above it; the measured number falls inside the stated range.
By their numbers in this assay, from the lowest: compounds 1 and 2 (each within the scatter of the next); then compounds 4 and 3 (each within the scatter of the next).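

In this assay, replacing heptyl with phenoxy on a saturated chain carbon, six bonds along the chain from a carbonyl carbon, gives a 2.6-fold higher number from compound 2 to compound 4 (0.42 log units; beyond the scatter), so a second aromatic replacement at this place goes the same way as a 3.6-fold higher number from compound 2 to compound 3 (0.56 log units; beyond the scatter). The new comparison is between the two aromatic groups themselves, and it gives a 1.4-fold lower number from compound 3 to compound 4 (0.14 log units; within the scatter), so at this place the series does not separate phenoxy from phenyl, even though phenoxy carries one hydrogen-bond acceptor and phenyl none. Nothing at hand explains either step.

Still open, going by these compounds, is whether this place responds to anything other than the presence of an aromatic ring: an amine or a carboxylic acid entering here could show whether the number moves further from that of compound 2 at 33 nM or returns toward it. A longer chain carrying the phenoxy group would also show whether the distance from the carbonyl carbon matters, which a single chain length cannot show.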